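Swapping one phenyl group when only a limit is known

The source may report more compounds than this note shows. Statements on the series, on what has been measured and on what is new or still open speak of the compounds shown alone.

In a functional assay on Bel-7402 cells (Homo sapiens) for cytotoxicity, read by MTT assay, with a stated time of 48 h (a higher number here means a weaker inhibitor, a lower number a stronger inhibitor), compound 1 `COc1ccc(-c2c[nH]c(=O)n2-c2cc(OC)c(OC)c(OC)c2)cc1` is recorded as "not determined" (no result reported), and compound 2 `COc1ccc(-c2c[nH]c(=O)n2-c2cc(OC)c(OC)c(OC)c2)cc1OC` is recorded as "not determined" (no result reported). Neither of them therefore offers a number to compare with.

Compound 3 `COc1cc(NC(=O)n2cc(-c3ccc(O)cc3)n(-c3cc(OC)c(OC)c(OC)c3)c2=O)cc(OC)c1OC` gives > 50000 nM, which is a limit of the assay and not a number. Within the data shown here, it is the only reading available so far: the limit of > 50000 nM in this assay, at which 1 of the 3 values shown sits. Among the measured compounds shown here, no step between two measured compounds exists either, so there is no direct measure of how much a change to this structure matters.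

Compound 4 `COc1ccc(-c2cn(C(=O)Nc3cc(OC)c(OC)c(OC)c3)c(=O)n2-c2cc(OC)c(OC)c(OC)c2)cc1N` keeps the rest of compound 3 and changes one group. It carries 3-amino-4-methoxyphenyl in place of 4-hydroxyphenyl, on an aromatic carbon of a five-membered aromatic ring with 2 nitrogen, next to the ring atom that bears a 3,4,5-trimethoxyphenyl group (3-amino-4-methoxyphenyl in place of 4-hydroxyphenyl on an aromatic carbon).

The expectation here leans on compound 3 and its limit of > 50000 nM, the sole anchor available, so it is a cautious one. In this assay, a clear step beyond the usual scatter toward a stronger inhibitor is expected, estimated as an at least 12-fold lower number from compound 3 to compound 4 (1.09 log units; beyond the scatter). With so little data, staying at the limit remains a real possibility.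

For compound 4 the estimated value is 4000 nM, with an expected range from 200 nM to 50000 nM.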

Compound 4, half-maximal inhibitory concentration: 10100 nM
Beside the measured number, compound 4's estimate is 2.5-fold (0.40 log units) below it; measured number inside the range.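

In this assay, among these compounds, this aromatic carbon of the five-membered ring turns out to respond to a change of group: 3-amino-4-methoxyphenyl in place of 4-hydroxyphenyl gives an at least 4.9-fold lower number from compound 3 to compound 4 (0.69 log units; beyond the scatter), the first measured step in this small set. Among the compounds shown here, compound 4, at 10100 nM, also supplies the first true number here, so later changes to this shared core can be compared with a measured value. Going by these compounds, compound 3 carries a limit and not a number, so the printed step gives only the smallest size the change can have, and its full size remains unknown: the limit of > 50000 nM in this assay, at which 1 of the 4 values shown sits.

The swap alters the phenyl ring in more than one way at once, so the compounds shown cannot separate what the 3-amino group contributes from what the 4-methoxy group contributes. For the compounds shown here, whether a 3-aminophenyl group or a 3-hydroxy-4-methoxyphenyl group at this same carbon would give a similar number stays open, and no measured reason for the step is available, since a single pair can show only that the change matters here.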